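The compounds below may be only part of what the source reports. "The series", "measured", "known", "first", "only" and "open" are said of these compounds alone.

Going by the values given here, in a toxicity assay on WI-38 cells (Homo sapiens) for inhibition, read by MTT assay, with a stated time of 48 h (a lower number here means a stronger inhibitor, a higher number a weaker inhibitor), three compounds sharing one core have numbers so far. Compound 1 (`Cc1ccc(/C=C2\SC(=O)N(CC(=O)Nc3c(C)n(C)n(-c4ccccc4)c3=O)C2=O)cc1`) gives 83700 nM, compound 2 (`Cc1c(NC(=O)CN2C(=O)S/C(=C\c3ccc([N+](=O)[O-])cc3)C2=O)c(=O)n(-c2ccccc2)n1C`) gives 43800 nM, and compound 3 (`Cc1c(NC(=O)CN2C(=O)S/C(=C\c3ccc(Br)cc3)C2=O)c(=O)n(-c2ccccc2)n1C`) gives 66700 nM. Compound 3 does not stand apart from the other two, as the steps to it are a 1.3-fold lower number from compound 1 to compound 3 (0.10 log units; within the scatter) and a 1.5-fold higher number from compound 2 to compound 3 (0.18 log units; within the scatter).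

Compound 4 (`Cc1cc(C)c(/C=C2\SC(=O)N(CC(=O)Nc3c(C)n(C)n(-c4ccccc4)c3=O)C2=O)c(C)c1`) has not yet been measured. It differs from compound 3 in one group: 2,4,6-trimethylphenyl in place of 4-bromophenyl on a double-bonded chain carbon bound to a double-bonded ring carbon.

Among the compounds with values here, no measured compound carries 2,4,6-trimethylphenyl, so the evidence is indirect. The closest guide is the set of swaps on the same aromatic ring, which also include a 1.9-fold lower number from compound 1 to compound 2 (0.28 log units; within the scatter). Methyl, nitro and bromo in these three compounds all stay within the scatter of one another. Compound 1 is the nearest relative. It also carries methyl. In this assay, no step beyond the scatter is therefore expected, and the estimated step is a 1.0-fold higher number from compound 3 to compound 4 (0.02 log units; within the scatter). For compound 4, the expected value is 70000 nM, with an estimated range from 35000 nM to 130000 nM.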

Compound 4, half-maximal inhibitory concentration: 39100 nM
Compound 4: middle estimate off by 1.8-fold (0.25 log units), on the high side, within the range that was stated.
By their numbers in this assay, from the lowest: compounds 4, 2, 3 and 1 (each within the scatter of the next, the first and the last beyond it).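

In this assay, the step of a 2.1-fold lower number from compound 1 to compound 4 (0.33 log units; beyond the scatter) is the only one in this set that passes the scatter, though it remains modest. The other two steps, a 1.7-fold lower number from compound 3 to compound 4 (0.23 log units; within the scatter) and a 1.1-fold lower number from compound 2 to compound 4 (0.05 log units; within the scatter), stay within it, so at this chain carbon 2,4,6-trimethylphenyl can be told apart from 4-methylphenyl but not from 4-bromophenyl or 4-nitrophenyl. No measurement shown here gives a reason for the difference from 4-methylphenyl.

On these data alone, all four compounds keep a six-membered aromatic ring of carbon only at this place, so it remains open how an amine or a carboxylic acid on that ring would behave. As far as these compounds go, it is equally open whether a longer chain in place of the ring would leave the number within the same scatter.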